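A few compounds are considered here, and "the series" means these few. Any claim that something is new, unique, unknown or untested is made for them only; others in the source may bear on it.

Measured in a functional assay on HL-60 cells (Homo sapiens) for cytotoxicity, read by WST assay, with a stated time of 48 h; on this read-out higher numbers stand for weaker inhibition and lower numbers for stronger inhibition:
- compound 1 `O[C@@H](c1ccccc1)[C@H]1CO[C@H](c2ccccc2)[C@@H](C/C=C/c2ccccn2)C1` gives 36400 nM.
- compound 2 `O[C@@H](c1ccccc1)[C@H]1CO[C@H](c2ccccc2)[C@@H](C/C=C/c2ccncc2)C1` reaches only the assay limit, > 100000 nM.
- compound 3 `COc1ccc(/C=C/C[C@@H]2C[C@@H]([C@@H](O)c3ccc(OC)c(OC)c3)CO[C@H]2c2ccc(OC)c(OC)c2)cc1OC` gives 26000 nM.

Among the measured compounds shown here, compound 2 stands at the limit of this assay (the limit of > 100000 nM in this assay, at which 1 of the 3 values shown sits), so it has no number of its own, and the only thing the measurements say of it is the step of an at least 2.7-fold higher number from compound 1 to compound 2 (0.43 log units; beyond the scatter), which lies beyond the scatter. Compound 4 `COc1ccccc1/C=C/C[C@H]1C[C@@H]([C@@H](O)c2ccccc2)CO[C@@H]1c1ccccc1` differs from compound 2 in a single place: 2-methoxyphenyl in place of pyridin-4-yl on a double-bonded chain carbon bound to a double-bonded chain carbon. For the measured compounds named here, the one measured step at this place is an at least 2.7-fold higher number from compound 1 to compound 2 (0.43 log units; beyond the scatter), where pyridin-4-yl took the place of pyridin-2-yl and inhibition weakened past the point where a number was obtained. The step to compound 4 moves away from pyridin-4-yl again, into a carbon-only aromatic ring; compound 3, which carries a carbon-only aromatic ring at this place although it also differs elsewhere, gives 26000 nM, and compound 1 with pyridin-2-yl gives 36400 nM. For compound 4 the expectation is therefore a return to a measurable number, a step of about an at least 3.3-fold lower number from compound 2 to compound 4 (0.52 log units; beyond the scatter) towards stronger inhibition, with some chance that the assay again reports only its limit. Compound 4 is estimated at 30000 nM, expected between 10000 nM and 100000 nM.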

Compound 4, half-maximal inhibitory concentration: 10100 nM
For compound 4 the middle estimate is 3.0-fold (0.47 log units) above the measured one; the range from low to high includes it.
By their numbers in this assay, from the lowest: compound 4; then compounds 3 and 1 (each within the scatter of the next). At a limit, above all of these: compound 2.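

Compound 2 carries a limit and not a number: the limit of > 100000 nM in this assay, at which 1 of the 4 values shown sits. In this assay the change to 2-methoxyphenyl on a double-bonded chain carbon bound to a double-bonded chain carbon gives a measurable number, and the step, an at least 9.9-fold lower number from compound 2 to compound 4 (0.99 log units; beyond the scatter), is therefore only a minimum size. The firmer reading is a 3.6-fold lower number from compound 1 to compound 4 (0.56 log units; beyond the scatter), which rests on two measured numbers and shows that this position tolerates more than a choice between pyridine isomers: a carbon-only aromatic ring bearing a methoxy group gives stronger inhibition than pyridin-2-yl, something the pair compound 1 and compound 2 could not show.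

Still open, on these data alone, is whether this gain belongs to the carbon-only ring itself or to its methoxy group, a question that a plain phenyl at this place on the core of compound 4 would settle. Also open, as far as these compounds go, is how far the position accepts other groups on that ring, such as an amine or a carboxylic acid in place of the methoxy group.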